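The source may hold more compounds than are shown below. What is called first, only, known or untested is meant among the compounds shown, and "the series" means these compounds.

Measured in a functional assay on cells (Platelet, Homo sapiens) for inhibition; a lower number here means a stronger inhibitor, a higher number a weaker inhibitor:
Compound 1 `CCOC(=O)c1cccc(-c2n[nH]c3ccccc23)c1`: > 10000 nM
Compound 2 `CCOC(=O)c1ccc(-c2nn(C)c3ccccc23)cc1`: > 10000 nM

Both entries are limits of the assay and not numbers, so neither compound can be ranked against the other. The picture so far is simply (the limit of > 10000 nM in this assay, at which 2 of the 2 values shown sit). For compound 2, the starting point here, this assay gives > 10000 nM, and that limit is all that is known of its strength.

Compound 3 `CCOC(=O)c1ccc(-c2nn(Cc3ccccc3Cl)c3ccccc23)cc1` keeps the rest of compound 2 but changes one substituent. It carries 2-chlorophenyl in place of hydrogen on a saturated chain carbon bound to an aromatic nitrogen, which turns methyl into 2-chlorobenzyl: 2-chlorophenyl in place of hydrogen on a saturated chain carbon bound to an aromatic nitrogen.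

Going by the values given here, no pair of measured compounds shows what a change like this does, so the size of the step is an informed guess. A modest gain in inhibition is expected, enough to bring a real number into view, although another limit is quite possible. The expected change is an at least 1.6-fold lower number from compound 2 to compound 3 (0.22 log units; that floor lies within the scatter). Compound 3 is estimated at 6000 nM, with an expected range from 1000 nM to 20000 nM.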

Compound 3, half-maximal inhibitory concentration: > 10000 nM
Compound 3: a limit, no number (the forecaster's own chance of this, stated with the estimate: 45%); middle value at least 1.6-fold (0.22 log units) away from the limit.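

Compound 2 and compound 3 each give only a limit in this assay, not a number, so the step from methyl to 2-chlorobenzyl cannot be read. All the compounds now stand in the same place: the limit of > 10000 nM in this assay, at which 3 of the 3 values shown sit. The compounds shown leave open how strongly any of them inhibits and which change, if any, would produce a measurable value.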